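The compounds below may be only part of what the source reports. "The series", "measured", "known", "first", "only" and "open" are said of these compounds alone.

Measured compounds:
Compound 1 `CCOC(=O)CNC(=O)NC1=CS(=O)(=O)O[C@@]12[C@@H](CO[Si](C)(C)C(C)(C)C)O[C@@H](n1cc(C)c(=O)n(C)c1=O)[C@@H]2O[Si](C)(C)C(C)(C)C` gives 5020 nM in a functional assay on CCRF-CEM cells (Homo sapiens); a lower number here means that less compound is tolerated, a higher number that more compound is tolerated.
Compound 2 `Cc1cn([C@@H]2O[C@@H]3COC4(O)CS(=O)(=O)O[C@@]34[C@H]2O)c(=O)[nH]c1=O` gives 100000 nM in this assay.
Compound 3 `Cc1cn([C@@H]2O[C@@H]3COC4(O)CS(=O)(=O)O[C@@]34[C@H]2O[Si](C)(C)C(C)(C)C)c(=O)[nH]c1=O` gives 100000 nM in this assay.

Compound 1 stands lowest of the three numbers in this assay; compound 2 and compound 3 both sit far above it, beyond the scatter. Within the data shown here, the one step measured within a single change, no change at the digits printed from compound 2 to compound 3 (within the scatter), concerns a silyl group on an oxygen and leaves the number unchanged. Among the measured compounds shown here, compound 1 differs from compound 2 and compound 3 in several places at once, so no single step ties it to them.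

Compound 4 `Cc1cn([C@@H]2O[C@H](CO[Si](C)(C)C(C)(C)C)[C@@]3(OS(=O)(=O)C=C3NCC(=O)C(N)=O)[C@H]2O[Si](C)(C)C(C)(C)C)c(=O)n(C)c1=O` has not yet been measured. It differs from compound 1 only at the amine nitrogen: (carbamoylcarbonyl)methyl in place of ((ethoxycarbonyl)methyl)carbamoyl on an amine nitrogen. For the measured compounds named here, no measured step touches this position, and the step of no change at the digits printed from compound 2 to compound 3 (within the scatter) at a different site says nothing about it. With nothing to guide the direction, the expectation is that compound 4 stays near compound 1, and the estimated step of a 1.6-fold higher number from compound 1 to compound 4 (0.20 log units; within the scatter) is taken as small relative to the wide range allowed. Compound 4 is therefore expected to give about 8000 nM in this assay, with a range from 2000 nM to 40000 nM.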

Compound 4, half-maximal cytotoxic concentration: 9960 nM
Compound 4: middle estimate off by 1.2-fold (0.10 log units), on the low side; the measured number falls inside the stated range.
By their numbers in this assay, from the lowest: compounds 1 and 4 (each within the scatter of the next); then compounds 2 and 3 (each within the scatter of the next).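

In this assay, putting (carbamoylcarbonyl)methyl in place of ((ethoxycarbonyl)methyl)carbamoyl on the amine nitrogen gives a 2.0-fold higher number from compound 1 to compound 4 (0.30 log units; within the scatter), the first step read at this position. It shows that this substituent can be exchanged for one with fewer heavy atoms and fewer hydrogen-bond acceptors, while keeping the same count of hydrogen-bond donors, without the half-maximal cytotoxic concentration moving beyond the usual scatter. Nothing available accounts for this outcome or links it to any property of either group.

This single exchange leaves open whether the position tolerates other kinds of substituent, such as a free carboxylic acid, a primary amine or a longer alkyl chain on the same nitrogen, and whether any of them would shift the number beyond the scatter. It also leaves open how the silyl ethers on the core of compound 1 contribute, as the only silyl step shown belongs to a different pair of compounds, and no step removes a silyl group while this substituent is present.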